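Halogen swap on a hydrazone, ortho versus para

The source may hold more compounds than are shown below. What is called first, only, known or untested is meant among the compounds shown, and "the series" means these compounds.

Three hydrazones sharing one core have been tested, and a fourth awaits its number. Compound 1 `O=C(N/N=C/c1ccccc1F)c1cnccn1` carries a fluoro group, and in an ADME assay on J774 cells (Mus musculus) for cytotoxicity, read by MTT assay, with a stated time of 48 h, tested at 150 ug/mL (a higher number here means a weaker effect of the compound at the concentration tested, a lower number a stronger effect), compound 1 gives 81%. Compound 3 `O=C(N/N=C/c1ccccc1Br)c1cnccn1` is its bromo counterpart: the change is bromo in place of fluoro on an aromatic carbon, and with it the step of a number 10 percentage points higher from compound 1 to compound 3 (within the scatter) is small. Compound 2 `O=C(N/N=C/c1ccc(F)cc1)c1cnccn1` is built from the same atoms as compound 1, joined differently; the difference between the two cores is not broken down here. In this assay compound 2 gives 71%, and compound 3 gives 91%, so compound 2 and compound 3 are separated by a gap beyond the scatter, while compound 2 and compound 1 are not.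

Compound 4 `O=C(N/N=C/c1ccc(Br)cc1)c1cnccn1` has not yet been measured. From compound 2 it differs by bromo in place of fluoro on an aromatic carbon. For the measured compounds named here, this is the same kind of change as the one from compound 1 to compound 3, but not the same: there the bromo group sits ortho to a large group, here it sits para to a large group. Going by the values given here, with only one earlier example of the swap to lean on, the expectation for compound 4 rests on that example, so the step from compound 2 to compound 4 is estimated to resemble it, a number 9 percentage points higher from compound 2 to compound 4 (within the scatter), in this assay. Compound 4 is accordingly expected to show about 80%, with a plausible range from 65% to 95%.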

Compound 4, a percentage reported as activity, at one concentration (the size of the read-out at that concentration, not a potency): 94%
Compound 4: the middle estimate sits 14 percentage points below what was measured; low and high end bracket the measured number.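

On the core of compound 2, putting bromo in place of fluoro gives, in this assay, a number 23 percentage points higher from compound 2 to compound 4 (beyond the scatter), and in this assay a higher number means a weaker effect at the concentration tested. Set beside the earlier example of the same swap on the core of compound 1, the new step cannot be told apart from it, even though only the new step on its own stands clear of the scatter: the same change on two cores in this assay, a number 10 percentage points higher (within the scatter) from compound 1 to compound 3 and a number 23 percentage points higher (beyond the scatter) from compound 2 to compound 4, 13 percentage points apart, within the scatter of two such steps. This shows that the two cores give no sign of responding differently to the swap, but it does not fix a size for the step, and two pairs are too few to promise the same result on any further core.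

The compounds shown carry only fluoro or bromo on the six-membered aromatic ring, so it remains open what a chloro group, a methoxy group, an amine or a carboxylic acid would do in the same place. As far as these compounds go, each number is also a reading at one concentration and not a potency, so how these compounds compare across a range of concentrations remains open too.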